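Amide substituent changes on the pyrrole carboxamide of a pyrimidine series

A few compounds are considered here, and "the series" means these few. Any claim that something is new, unique, unknown or untested is made for them only; others in the source may bear on it.

Compound 2 `COc1cc(-n2cccc2C(=O)NCCO)ccc1Nc1ncc(Cl)c(Nc2ccccc2NS(C)(=O)=O)n1`: 34 nM
Compound 1 `CCN1CCN(C(=O)c2cccn2-c2ccc(Nc3ncc(Cl)c(Nc4ccccc4NS(C)(=O)=O)n3)c(OC)c2)CC1`: 1130 nM

Compound 2 `COc1cc(-n2cccc2C(=O)NCCO)ccc1Nc1ncc(Cl)c(Nc2ccccc2NS(C)(=O)=O)n1` has the lower of the two numbers measured in a functional assay on NCI-H2228 cells (Homo sapiens) for antiproliferative activity, read by MTT assay, with a stated time of 72 h; a higher number here means a weaker inhibitor, a lower number a stronger inhibitor; compound 2 gives 34 nM, while compound 1 `CCN1CCN(C(=O)c2cccn2-c2ccc(Nc3ncc(Cl)c(Nc4ccccc4NS(C)(=O)=O)n3)c(OC)c2)CC1` gives 1130 nM. Within the data shown here, the single measured step, a 33-fold lower number from compound 1 to compound 2 (1.52 log units; beyond the scatter), shows that the group on this carbonyl carbon can shift the number by a large amount. Compound 3 `COc1cc(-n2cccc2C(=O)N(C)C)ccc1Nc1ncc(Cl)c(Nc2ccccc2NS(C)(=O)=O)n1` differs from compound 2 at the same carbonyl carbon: dimethylamino in place of (2-hydroxyethyl)amino on a carbonyl carbon. Among the measured compounds shown here, only the step from compound 1 to compound 2 bears on this change, and it was large, though in a different direction of substitution. With nothing further to go on, compound 3 is expected to fall somewhat short of compound 2, with a wide range: the estimated step is a 2.6-fold higher number from compound 2 to compound 3 (0.42 log units; beyond the scatter). The estimate for compound 3 in this assay is 90 nM, between 20 nM and 450 nM.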

Compound 3, half-maximal inhibitory concentration: 54 nM
For compound 3 the middle estimate is 1.7-fold (0.22 log units) above the measured one; measured number inside the range.
By their numbers in this assay, from the lowest: compounds 2 and 3 (each within the scatter of the next); then compound 1.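

In this assay, the step of a 1.6-fold higher number from compound 2 to compound 3 (0.20 log units; within the scatter) shows that this carbonyl carbon tolerates dimethylamino in place of (2-hydroxyethyl)amino, although the hydrogen-bond donors and the acceptor counted for the leaving group are absent from the entering one. The step of a 21-fold lower number from compound 1 to compound 3 (1.32 log units; beyond the scatter) is large as well, so among the three compounds the group 4-ethylpiperazin-1-yl stands alone at the high number, with both open-chain groups well clear of it. Nothing available explains why these groups give these numbers.

Going by these compounds, whether the high number of compound 1 goes with the piperazine ring itself or with its ethyl-bearing nitrogen remains open, and a morpholine ring or a plain piperazine would speak to that. Also open, on these data alone, is how a longer chain ending in a primary amine or a carboxylic acid would read at this carbonyl carbon.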